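Amide in Place of Benzyl on the Ring Nitrogen

The source may hold more compounds than are shown below. What is called first, only, known or untested is meant among the compounds shown, and "the series" means these compounds.

Compound 1, `Fc1ccc(C(SCCNC2CCN(Cc3ccc(Cl)cc3)CC2)c2ccc(F)cc2)cc1`: 45.5 nM
Compound 2, `[O-][S+](CCNC1CCN(Cc2ccc(F)cc2)CC1)C(c1ccc(F)cc1)c1ccc(F)cc1`: 26.5 nM

Of the compounds shown here, two have been measured in an assay on membranes from Cortex for displacement of a labelled ligand from Sigma non-opioid intracellular receptor 1 (Cavia porcellus), read by scintillation counting, with a stated time of 120 min; a higher number here means a weaker inhibitor, a lower number a stronger inhibitor. Compound 1 gives 45.5 nM in this assay, and compound 2 gives 26.5 nM. Compound 2 has the lower of the two numbers, but the gap to compound 1 lies within the usual scatter, so the two cannot be ordered with confidence.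

Compound 3, `O=C(c1ccc(F)cc1F)N1CCC(NCC[S+]([O-])C(c2ccc(F)cc2)c2ccc(F)cc2)CC1`, has not yet been measured. It differs from compound 2 in one place: (2,4-difluorophenyl)carbonyl in place of 4-fluorobenzyl on an amine nitrogen in a ring. The amine nitrogen in the ring that carried a benzyl group in compound 2 thus becomes part of an amide in compound 3, while the secondary amine in the chain is kept. Within the data shown here, no measured pair shows what such a change does here.

The account expects a step from compound 2 to compound 3 of a 3.2-fold higher number from compound 2 to compound 3 (0.51 log units; beyond the scatter), toward a weaker inhibitor, beyond the scatter. For compound 3 the estimate in this assay is 85 nM, with a range from 25 nM to 300 nM.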

Compound 3, inhibition constant: 171 nM
Compound 3: the middle estimate sits 2.0-fold (0.30 log units) below what was measured; the measured number falls inside the stated range.
By their numbers in this assay, from the lowest: compounds 2 and 1 (each within the scatter of the next); then compound 3.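

On an amine nitrogen in a ring, (2,4-difluorophenyl)carbonyl in place of 4-fluorobenzyl gives a 6.5-fold higher number from compound 2 to compound 3 (0.81 log units; beyond the scatter) in this assay and so moves toward a weaker inhibitor, beyond the scatter. Among these compounds, this is the first reading at this position, and it shows that the group on the ring nitrogen matters, though compound 3, which keeps the secondary amine in the chain, still gives a measurable inhibition constant. Nothing available explains the size of this step.

The change brings in a carbonyl and a second fluorine together, so the compounds shown cannot divide the step between them. From the compounds shown here alone, a difluorobenzyl group or a fluorobenzoyl group on the same nitrogen would separate the two, and how a sulfonyl group or a urea would behave there remains open.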